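Swapping a Thiophene for Phenyl on the Shared Core

This account rests on a few compounds, and the source may have more. Where it says the series, first, only, none or still open, it means among the compounds named here.

Three compounds with a common core have been examined in a functional assay on DU-145 cells (Homo sapiens) for cytotoxicity, read by CCK-8 assay and cell counting, with a stated time of 2 days; on this read-out higher numbers stand for weaker inhibition and lower numbers for stronger inhibition. Compound 1 `Oc1cccc(-c2cc(-c3cccnc3)nc(-c3cccc(Cl)c3)c2)c1` has "not determined" (no result reported) in this assay. Compound 2 `Oc1cccc(-c2cc(-c3ccccc3)nc(-c3ccc(Cl)cc3)c2)c1` gives 11200 nM in this assay. Compound 3 `Oc1cccc(-c2cc(-c3cccc(Cl)c3)nc(-c3cccs3)c2)c1` gives 2650 nM, the lowest of the two numbers available; the gap to compound 2 lies beyond the usual scatter.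

Compound 4 `Oc1cccc(-c2cc(-c3ccccc3)nc(-c3cccc(Cl)c3)c2)c1` is built from compound 3 by one change, (phenyl in place of thiophen-2-yl on an aromatic carbon), that is, phenyl in place of thiophen-2-yl on an aromatic carbon next to the ring nitrogen. Among the measured compounds shown here, no measured pair within this set shows the same change, so the size of the step can only be guessed. The expected step from compound 3 to compound 4 is a 1.7-fold higher number from compound 3 to compound 4 (0.23 log units; within the scatter), a small move toward a higher number that may well fall within the scatter. For compound 4, the estimated value in this assay is 4500 nM, within a range from 1500 nM to 14000 nM.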

Compound 4, half-maximal inhibitory concentration: 2750 nM
The estimate for compound 4 lay 1.6-fold (0.21 log units) above the measured number; measured number inside the range.
By their numbers in this assay, from the lowest: compounds 3 and 4 (each within the scatter of the next); then compound 2.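

In this assay putting phenyl in place of thiophen-2-yl on the aromatic carbon next to the ring nitrogen gives a 1.0-fold higher number from compound 3 to compound 4 (0.02 log units; within the scatter) and so, within the scatter, these two aromatic rings cannot be told apart at this position. The placement of the chlorine on the neighbouring ring shows a clearer effect, since 3-chlorophenyl in place of 4-chlorophenyl gives a 4.1-fold lower number from compound 2 to compound 4 (0.61 log units; beyond the scatter) and that step lies beyond the scatter. No measurement is available to explain either result.

The compounds shown all carry an aromatic ring at the position next to the ring nitrogen, so what an amine or a carboxylic acid would do there remains open. On these data alone, it is also open whether the 3-hydroxyphenyl group could give way to a 3-methoxyphenyl group with the number staying the same.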